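This account rests on a few compounds, and the source may have more. Where it says the series, first, only, none or still open, it means among the compounds named here.

Measured so far:
- compound 1, `CCN(CC)c1ccc2cc(C(=O)c3ccc(N4CCN(C(=O)CN5CCN(C(=O)CCl)CC5)CC4)cc3)oc2c1`: 3060 nM in a functional assay on A549 cells (Homo sapiens) for cytotoxicity, read by MTT assay, with a stated time of 48 h; a lower number here means a stronger inhibitor, a higher number a weaker inhibitor
- compound 2, `CCN(CC)c1ccc2cc(C(=O)c3ccc(N4CCN(C(=O)CN5CCN(S(=O)(=O)C6CC6)CC5)CC4)cc3)oc2c1`: 17300 nM

For the measured compounds named here, on these two numbers compound 2 stands highest, that is, as the weaker inhibitor of the pair; the only other compound, compound 1, sits at the lower number, and the gap between them is a 5.7-fold higher number from compound 1 to compound 2 (0.75 log units; beyond the scatter). That single step, the exchange of (chloromethyl)carbonyl for cyclopropylsulfonyl on an amine nitrogen in a ring, is all that is known about how this position responds to a new group.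

Compound 3, `CCN(CC)c1ccc2cc(C(=O)c3ccc(N4CCN(C(=O)CN5CCN(Cc6ccc(C(F)(F)F)cc6)CC5)CC4)cc3)oc2c1`, has not been measured in this assay. Its difference from compound 2 is 4-(trifluoromethyl)benzyl in place of cyclopropylsulfonyl on an amine nitrogen in a ring. The one measured step touches the same ring nitrogen, and it was of modest size, so a change there is not expected to be silent; but neither group of compound 3 has been measured at that place, so the direction rests on no shown step. Compound 3 is therefore expected to land near compound 2, with a wide range, the estimated step being a 1.9-fold lower number from compound 2 to compound 3 (0.28 log units; within the scatter). The estimate for compound 3 in this assay is 9000 nM, within 2500 nM to 35000 nM.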

Compound 3, half-maximal inhibitory concentration: 20100 nM
The estimate for compound 3 lay 2.2-fold (0.35 log units) below the measured number, and the stated range covers the measured number.
By their numbers in this assay, from the lowest: compound 1; then compounds 2 and 3 (each within the scatter of the next).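

In this assay, the new result shows that this ring nitrogen does not respond to every exchange: the step to 4-(trifluoromethyl)benzyl in place of cyclopropylsulfonyl is a 1.2-fold higher number from compound 2 to compound 3 (0.07 log units; within the scatter), although the entering group has 11 heavy atoms and 0 hydrogen-bond acceptors, against 6 heavy atoms and 2 hydrogen-bond acceptors for the group that leaves. The (chloromethyl)carbonyl group now stands apart from two different replacements, not just one, with the second comparison being a 6.6-fold higher number from compound 1 to compound 3 (0.82 log units; beyond the scatter), which leaves compound 1 as the strongest inhibitor of the three. Nothing shown offers an explanation for either the closeness of the one pair or the gap to compound 1.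

The compounds shown leave open whether the lower number of compound 1 depends on the chlorine of its (chloromethyl)carbonyl group or on the carbonyl, a question that a plain acetyl group on the same nitrogen would address. They also leave open whether the trifluoromethyl group matters within the benzyl substituent, and how an unsubstituted benzyl group or a free amine at this ring nitrogen would compare.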